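Working notes: from compound 2 to compound 3

The compounds below may be only part of what the source reports. "The series", "measured", "known", "first", "only" and "open" are said of these compounds alone.

Values so far in a physicochemical assay for solubility, in phosphate buffer, at pH 6.5; on this read-out higher numbers stand for higher solubility and lower numbers for lower solubility
compound 1 `CNc1nc(NCCCN(C)C)c2sc(-c3ccc(S(C)(=O)=O)cc3)cc2n1` gives 25 ug/mL
compound 2 `CNc1nc(NCCCN(C)C)c2sc(-c3cccc(C#N)c3)cc2n1` gives 25 ug/mL

Compound 2 stands level with compound 1 in this assay with no difference at the digits reported. Among the measured compounds shown here, compound 3 `CNc1nc(NCCCN(C)C)c2sc(-c3ccc(C(C)=O)cc3)cc2n1` is the next point and has no measurement yet. It carries 4-acetylphenyl in place of 3-cyanophenyl on an aromatic carbon of a five-membered aromatic ring with 1 sulfur, next to the ring sulfur, and the full count reads 4-acetylphenyl in place of 3-cyanophenyl on an aromatic carbon for this change.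

For the measured compounds named here, no measured step isolates a single change, so the evidence for its size is thin. The values in hand offer only a level pair, with compound 1 at 25 ug/mL and compound 2 at 25 ug/mL within the scatter of each other. The leaving and entering groups also match in their hydrogen-bond counts and in carrying no net charge. On that basis no shift beyond the scatter is expected in this assay in either direction. The expected step is no change at the digits printed from compound 2 to compound 3 (within the scatter) and remains an estimate only. For compound 3 the expected value is 25 ug/mL with an estimated range from 10 ug/mL to 60 ug/mL as the working figure.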

Compound 3, solubility: 12.5 ug/mL
Estimate against measurement, compound 3: 2.0-fold (0.30 log units) above, within the range that was stated.
By their numbers in this assay, from the lowest: compounds 3, 1 and 2 (each within the scatter of the next).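

In this assay, exchanging 3-cyanophenyl for 4-acetylphenyl at the aromatic carbon next to the ring sulfur gives a 2.0-fold lower number from compound 2 to compound 3 (0.30 log units; within the scatter). Acetyl in place of methylsulfonyl at the same carbon gives a 2.0-fold lower number from compound 1 to compound 3 (0.30 log units; within the scatter), so this read-out does not yet separate the three aryl groups at this position, and all of the steps available here stay within the scatter. No measurement of any property of these groups is available to bear on this result.

Compound 2 and compound 3 differ both in the group carried by the phenyl ring and in where it sits, so the step from one to the other cannot divide those two contributions, and a 3-acetylphenyl or 4-cyanophenyl group would be needed to do so. Going by these compounds, it also remains open whether a phenyl ring carrying a carboxylic acid or an amine at this carbon, or a plain unsubstituted phenyl, would take the read-out beyond the scatter, since every aryl group here carries a neutral substituent with no hydrogen-bond donor.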